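Adding a 4-phenylphenyl Group to a Piperazine Side Chain

A few compounds are considered here, and "the series" means these few. Any claim that something is new, unique, unknown or untested is made for them only; others in the source may bear on it.

Two measured compounds frame this step. Compound 1 `CN(Cc1ccc(-c2ccccc2)cc1)Cc1cn(C)c2ccc(CNc3ccc(F)cc3)cc12` gives 20200 nM in a functional assay on MCF7 cells (Homo sapiens) for antiproliferative activity, read by MTT assay, with a stated time of 72 h; a higher number here means a weaker inhibitor, a lower number a stronger inhibitor. Compound 2 `CN1CCN(Cc2cn(C)c3ccc(C(=O)Nc4ccc(F)cc4)cc23)CC1` gives 24700 nM in this assay, the highest of the two numbers, with compound 1 within the scatter of it. Compound 3 `Cn1cc(CN2CCN(Cc3ccc(-c4ccccc4)cc3)CC2)c2cc(C(=O)Nc3ccc(F)cc3)ccc21` differs from compound 2 by 4-phenylphenyl in place of hydrogen on a saturated chain carbon bound to an amine nitrogen in a ring. Among the compounds with values here, no measured step of this kind exists, so the expectation for compound 3 rests on compound 1 and compound 2 alone. The step of a 1.6-fold lower number from compound 2 to compound 3 (0.22 log units; within the scatter) is expected to be small, if anything toward a lower number. Compound 3 is estimated at 15000 nM, within 5000 nM to 45000 nM.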

Compound 3, half-maximal inhibitory concentration: 63900 nM
Compound 3: middle estimate off by 4.3-fold (0.63 log units), on the low side, and the stated range ends below it.
By their numbers in this assay, from the lowest: compounds 1 and 2 (each within the scatter of the next); then compound 3.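

Replacing hydrogen with 4-phenylphenyl on a saturated chain carbon bound to an amine nitrogen in a ring gives a 2.6-fold higher number from compound 2 to compound 3 (0.41 log units; beyond the scatter) in this assay, a modest step. This position therefore responds to the change, and the large all-carbon biaryl group weakens inhibition here rather than leaving it unchanged. That holds for this single pair only.

Nothing shown explains why the number rises. Going by these compounds, whether a carboxylic acid, an amine or a longer chain at this carbon would move the number the same way remains open.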